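Hydroxy to bromo on the 3-hydroxy-4-methoxybenzyl group

This account rests on a few compounds, and the source may have more. Where it says the series, first, only, none or still open, it means among the compounds named here.

Measured in a functional assay on MGC-803 cells (Homo sapiens) for antiproliferative activity, read by MTT assay, with a stated time of 48 h; on this read-out higher numbers stand for weaker inhibition and lower numbers for stronger inhibition:
- compound 1 `COc1ccc(CN(C(=O)CSc2nc3ccccc3s2)c2cc(OC)c(OC)c(OC)c2)cc1O` gives 35 nM
- compound 2 `COc1ccc2nc(SCC(=O)N(Cc3ccc(OC)c(O)c3)c3cc(OC)c(OC)c(OC)c3)sc2c1` gives 71 nM
- compound 3 `COc1ccc(CN(C(=O)CSc2nc3c(C)cccc3s2)c2cc(OC)c(OC)c(OC)c2)cc1O` gives 493 nM

Of these three, compound 1 gives the lowest number, and its steps to both neighbours lie beyond the scatter. The next compound to be tested in this assay is compound 4 `COc1ccc(CN(C(=O)CSc2nc3ccccc3s2)c2cc(OC)c(OC)c(OC)c2)cc1Br`. Its difference from compound 1 is this: bromo in place of hydroxy on an aromatic carbon. In words, bromo takes the place of hydroxy on an aromatic carbon, ortho to a methoxy group, so the 3-hydroxy-4-methoxybenzyl becomes 3-bromo-4-methoxybenzyl.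

Within the data shown here, no measured step touches this group, so the data offer no direct precedent for the change. The two steps from compound 1 bear on it only indirectly, as they show how far a single substitution elsewhere has moved the number. One is modest, a 2.0-fold higher number from compound 1 to compound 2 (0.31 log units; beyond the scatter), and the other is large, a 14-fold higher number from compound 1 to compound 3 (1.15 log units; beyond the scatter). Both go upward from compound 1, and with only these two steps the direction remains a weak guide. A moderate loss of potency is therefore expected, with wide uncertainty. The estimated size of the change is a 4.0-fold higher number from compound 1 to compound 4 (0.60 log units; beyond the scatter). For compound 4 the expected value is 140 nM, with an estimated range from 30 nM to 650 nM.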

Compound 4, half-maximal inhibitory concentration: 852 nM
The estimate for compound 4 lay 6.1-fold (0.78 log units) below the measured number; measured number above the stated range.
By their numbers in this assay, from the lowest: compound 1; then compound 2; then compounds 3 and 4 (each within the scatter of the next).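

In this assay the result shows that the group carrying the hydroxy is not a tolerant part of the molecule: replacing it with bromo gives a 24-fold higher number from compound 1 to compound 4 (1.39 log units; beyond the scatter) and ranks with the large step elsewhere in the molecule, a 14-fold higher number from compound 1 to compound 3 (1.15 log units; beyond the scatter) on the methyl exchange. A single heavy atom exchanged on the 3-hydroxy-4-methoxybenzyl group can therefore cost about as much as the methyl substitution, so potency in this series depends on this group as well as on the other end of the molecule. Hydroxy counts as a hydrogen-bond donor and acceptor while bromo counts as neither, but no measurement here ties that difference, or any other property of the two groups, to the loss, and this one step cannot separate the departure of hydroxy from the arrival of bromo.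

The compounds shown leave open whether the loss belongs to bromo alone or to any replacement of hydroxy, which an amino group, a fluoro group or a methoxy group on the same aromatic carbon would help to settle. They also leave open whether the same exchange would cost as much in the 6-methoxy-1,3-benzothiazol-2-yl series of compound 2.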